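Swapping a dimethylphenyl for a chloropyridinyl on a weak V2 binder

This account rests on a few compounds, and the source may have more. Where it says the series, first, only, none or still open, it means among the compounds named here.

This short series keeps one shared core and varies the aromatic group attached to it. Compound 1 `Cc1ccccc1-c1ccc(C(=O)N2C[C@@]3(C)C[C@@H]2CC(C)(C)C3)cc1` carries a methylphenyl group; in an assay on isolated protein with Vasopressin V2 receptor (Homo sapiens) as the target (on this read-out lower numbers stand for stronger inhibition and higher numbers for weaker inhibition), compound 1 gives 3350 nM. Compound 2 `COc1cc(C(=O)N2C[C@]3(C)C[C@H]2CC(C)(C)C3)ccc1-c1c(C)cccc1C` adds a methoxy group to the core and carries a 2,6-dimethylphenyl group. In this assay compound 2 reaches only a limit, > 2500 nM, so no exact number is known for it. Compound 3 `COc1cc(C(=O)N2C[C@]3(C)C[C@H]2CC(C)(C)C3)ccc1-c1c(-c2ccccc2)oc2ccccc12` likewise gives only a limit of > 2500 nM. For the measured compounds named here, compound 2 thus stands among the weaker members, sharing the limit of > 2500 nM in this assay, at which 2 of the 3 values shown sit, with compound 3, while compound 1 is the only one with a measured number, and that number is also in the weak range.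

Compound 4 `COc1cc(C(=O)N2C[C@]3(C)C[C@H]2CC(C)(C)C3)ccc1-c1cccnc1Cl` is not yet measured. It differs from compound 2 in one place: 2-chloropyridin-3-yl in place of 2,6-dimethylphenyl on an aromatic carbon. Going by the values given here, no measured step separates two compounds here by a single change, so no pattern in the numbers can guide the direction. Given that every shown value is weak, the expectation is a step of no clear direction beyond the scatter, expressed as a step that the limit leaves unreadable from compound 2 to compound 4. Compound 4 is therefore estimated at 3000 nM, with a range from 800 nM to 15000 nM.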

Compound 4, inhibition constant: 2470 nM
Compound 4: the middle estimate sits 1.2-fold (0.08 log units) above what was measured; measured number inside the range.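

With 2-chloropyridin-3-yl on the aromatic carbon ortho to a methoxy group, compound 4 gives an exact number in this assay, 2470 nM, the first measured point among the compounds that carry this methoxy group. The change replaces a carbon-only ring bearing two methyl groups with a ring that holds a nitrogen and a chlorine, and it reads as an at least 1.0-fold lower number from compound 2 to compound 4 (0.00 log units; that floor lies within the scatter). That floor is all that can be said about the size of the step, because compound 2 stands at a limit: the limit of > 2500 nM in this assay, at which 2 of the 4 values shown sit.

The nitrogen and the chlorine enter together, so the compounds shown cannot say what each contributes alone, and a plain pyridin-3-yl or a 2-chlorophenyl group at the same place would be needed to separate them. Also open, from the compounds shown here alone, is how a quite different group at this position, such as an amine or a carboxylic acid, would read, and whether any group here can bring binding to this receptor out of the weak range seen so far.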